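Notes on tolerated concentration across three benzyl variants

The source may report more compounds than this note shows. Statements on the series, on what has been measured and on what is new or still open speak of the compounds shown alone.

For the measured compounds named here, compound 3 `CCOC(=O)c1cnc(N2CCN(Cc3cccc(C(=O)OC)c3)CC2)nc1Oc1c(C)cc(-c2ccc(C#N)cc2)cc1C` is one of three compounds measured in an ADME assay on MT4 cells (Homo sapiens) for cytotoxicity, read by MTT assay, with a stated time of 4 days; a lower number here means that less compound is tolerated, a higher number that more compound is tolerated. In this assay compound 3 gives only a limit, > 125000 nM. Compound 1 `CCOC(=O)c1cnc(N2CCN(Cc3ccccc3C#N)CC2)nc1Oc1c(C)cc(-c2ccc(C#N)cc2)cc1C` also gives a limit here, > 125000 nM. Compound 2 `CCOC(=O)c1cnc(N2CCN(Cc3ccc(F)cc3)CC2)nc1Oc1c(C)cc(-c2ccc(C#N)cc2)cc1C` likewise gives a limit, > 117000 nM. All three values sit at limits, the limit of > 125000 nM in this assay, at which 2 of the 3 values shown sit, and (the limit of > 117000 nM in this assay, at which 1 of the 3 values shown sits), so the steps a step that the two limits leave unreadable from compound 1 to compound 2, a step that the two limits leave unreadable from compound 1 to compound 3 and a step that the two limits leave unreadable from compound 2 to compound 3 cannot be read in size. Compound 4 `CCOC(=O)c1cnc(N2CCN(Cc3ccccc3[N+](=O)[O-])CC2)nc1Oc1c(C)cc(-c2ccc(C#N)cc2)cc1C` is not yet measured; its change from compound 3 is 2-nitrophenyl in place of 3-(methoxycarbonyl)phenyl on a saturated chain carbon bound to an amine nitrogen in a ring. The measured steps bear on it only in that none gave a readable number, so no step beyond the scatter is expected in this assay. Compound 4 is estimated at 150000 nM, between 90000 nM and 300000 nM, most likely reported again as a limit. The step that the limit leaves unreadable from compound 3 to compound 4 is therefore expected to stay within the scatter.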

Compound 4, half-maximal cytotoxic concentration: >= 78700 nM
Compound 4: a limit, no number; the forecaster's own chance of this, stated with the estimate: 85%; the middle value lies beyond the limit too.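

For the compounds shown here, compound 4 also gives only a limit, and no step between it and compound 1, compound 2 or compound 3 can be read in size. In this assay the compounds shown leave open the concentration at which any of these four benzyl variants reaches half-maximal cytotoxicity.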